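This account rests on a few compounds, and the source may have more. Where it says the series, first, only, none or still open, it means among the compounds named here.

Measured so far:
compound 1 `O=S(=O)(CC1=NCCO1)C1C(c2ccc(Cl)cc2)=NN(c2ccccc2)C1c1ccc(Cl)cc1` — a functional assay, tested at 100 ug/mL; on this read-out higher numbers stand for a stronger effect at the one concentration tested and lower numbers for a weaker effect: "not active" (no number reported)
compound 2 `COc1ccc(-c2nn(-c3ccccc3)c(-c3ccc(C)cc3)c2S(=O)(=O)CC2=NCCS2)cc1` — this assay: "not active" (no number reported)
compound 3 `COc1ccc(C2=NOC(c3ccc(C)cc3)C2S(=O)(=O)CC2=NCCO2)cc1` — this assay: 70.9%

Compound 3 is the only one of the three with a number in this assay; compound 1 and compound 2 carry no number at all. Compound 4 `COc1ccc(C2=NOC(c3ccc(C)cc3)C2S(=O)(=O)CC2=NCCS2)cc1` is not yet measured. It differs from compound 3 in one place: a group of 5 heavy atoms (3 carbon, 1 nitrogen, 1 sulfur; one five-membered non-aromatic ring with 2 hetero atoms) in place of a group of 5 heavy atoms (3 carbon, 1 nitrogen, 1 oxygen; one five-membered non-aromatic ring with 2 hetero atoms), on a saturated chain carbon bound to a sulfonyl sulfur. Within the data shown here, no step between two measured compounds is available to size this swap, so the expectation rests on compound 3 alone, with compound 2 as the only measured bearer of the entering group, and it sits on a different core. The estimated step of a number 10.9 percentage points lower from compound 3 to compound 4 (beyond the scatter) is small, downward, and not beyond the scatter. Compound 4 is therefore expected near 60%, within 30% to 85%.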

Compound 4, a percentage reported as activity, at one concentration (the size of the read-out at that concentration, not a potency): 52.6%
For compound 4 the middle estimate is 7.4 percentage points above the measured one; the range from low to high includes it.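

Compound 3 and compound 4 share a core, and in this assay exchanging the oxygen-bearing ring for the sulfur-bearing ring, on a saturated chain carbon bound to a sulfonyl sulfur, gives a number 18.3 percentage points lower from compound 3 to compound 4 (beyond the scatter), the first measured size for this swap. The position therefore responds to a change of one hetero atom in the ring, while a clear read-out remains with either ring. Nothing measured here explains the drop.

Going by these compounds, whether the step carries over to other cores stays open, as compound 1 and compound 2 give no number. Also open, on these data alone, is how a dimethylamino group or a carboxylic acid would read in place of the ring on that carbon.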